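Amide series: pyrazole for isoxazole, plasma protein binding

The source may hold more compounds than are shown below. What is called first, only, known or untested is meant among the compounds shown, and "the series" means these compounds.

Among the compounds with values here, compound 1 `Cc1cc(C(C)NC(=O)c2[nH]cc(Cc3ccc(C(F)(F)F)nc3)c2C)no1` is one of two compounds measured in an ADME assay on a cell-free system (plasma, Homo sapiens) for protein binding; in that assay compound 1 gives 94.7%. The other measured compound, compound 2 `Cc1cc(Nc2ccc(S(F)(F)(F)(F)F)cc2)n2nc(C(F)(F)F)nc2n1`, gives 99.8% in this assay. On these two numbers compound 1 has the higher unbound fraction, and the gap to compound 2 is well beyond the scatter of the measurement.

Compound 3 `Cc1c(Cc2ccc(C(F)(F)F)nc2)c[nH]c1C(=O)NC(C)c1cnn(C)c1` is not yet measured. It differs from compound 1 in one place: 1-methyl-1H-pyrazol-4-yl in place of 5-methyl-1,2-oxazol-3-yl on a saturated chain carbon bound to an amide-type nitrogen and a saturated chain carbon. Both groups are five-membered aromatic rings with two hetero atoms, and the rest of the molecule, including the amide, is unchanged.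

Within the data shown here, no step between two measured compounds shows what such a swap does in this assay, so the direction rests on the structural change alone. The expectation is for a small move toward a higher unbound fraction, not beyond the scatter; the expected step is a 1.3-fold higher unbound fraction from compound 1 to compound 3 (0.12 log units; within the scatter). For compound 3 the estimated value in this assay is 93%, with a range from 87% to 96.5%.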

Compound 3, plasma protein binding in the Homo sapiens assay: 83%
For compound 3 the middle estimate is 2.4-fold (0.39 log units) (unbound fraction) below the measured one, and the stated range ends above it.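

This position on a saturated chain carbon bound to an amide-type nitrogen and a saturated chain carbon responds to the identity of the ring, even though the two rings match in their counts of heavy atoms, hydrogen-bond donors and acceptors and in having no net charge: in the Homo sapiens assay the swap gives a 3.2-fold higher unbound fraction from compound 1 to compound 3 (0.51 log units; beyond the scatter). In a physicochemical assay for solubility, in simulated intestinal fluid, with a stated time of 5 h, at pH 5.8 (a higher number here means a more soluble compound, a lower number a less soluble compound), compound 1 gives 47.8 ug/mL and compound 3 gives 158 ug/mL, so the same single change moves both read-outs beyond the scatter. The higher unbound fraction of compound 3 therefore comes with a higher solubility in the physicochemical assay: the measured solubility of compound 1, 47.8 ug/mL, and of compound 3, 158 ug/mL, a 3.3-fold higher number (0.52 log units; beyond the scatter)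

This link rests on a single matched pair, so it cannot show whether the two read-outs would keep moving together with other groups at this position. Going by these compounds, it also remains open how a phenyl ring, a pyridine ring, a morpholine or a carboxylic acid in place of 1-methyl-1H-pyrazol-4-yl would behave in these two assays, and whether the step would hold with the rest of the molecule changed.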